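Removing the group from compound 2's amine nitrogen

The source may hold more compounds than are shown below. What is called first, only, known or untested is meant among the compounds shown, and "the series" means these compounds.

Measured in a functional assay on MCF7 cells (Homo sapiens) for inhibition, read by MTT assay, with a stated time of 48 h; on this read-out lower numbers stand for stronger inhibition and higher numbers for weaker inhibition:
compound 1 `CCOC(=O)C1=C(N/N=C(/C(=O)Br)c2ccc(Br)cc2)Nc2[nH]nc(C)c2C1c1ccc(N(C)C)cc1` gives 61300 nM
compound 2 `CCOC(=O)C1=C(N/N=C(/Br)c2ccccc2)Nc2[nH]nc(C)c2C1c1ccc(N(C)C)cc1` gives 78400 nM

Compound 2, at 78400 nM, lies within the usual scatter of compound 1, so these two numbers cannot be ranked. Compound 3 `CCOC(=O)C1=C(N)Nc2[nH]nc(C)c2C1c1ccc(N(C)C)cc1` has not yet been measured. Its difference from compound 2 is this: a hydrogen atom in place of a group of 9 heavy atoms (7 carbon, 1 nitrogen, 1 bromine; one six-membered aromatic ring of carbon only), on an amine nitrogen. Within the data shown here, only one measured step bears on it, as it also changes the group on this amine nitrogen: a 1.3-fold higher number from compound 1 to compound 2 (0.11 log units; within the scatter). That step exchanged one large group for another and stayed within the scatter. Among the measured compounds shown here, no measured compound carries a bare hydrogen here, so this evidence is thin. No step beyond the scatter is expected, in either direction, though with real uncertainty. The expected change is a 1.1-fold lower number from compound 2 to compound 3 (0.05 log units; within the scatter). For compound 3, the estimate is 70000 nM, with an expected range from 25000 nM to 180000 nM.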

Compound 3, half-maximal inhibitory concentration: 5060 nM
For compound 3 the middle estimate is 14-fold (1.14 log units) above the measured one; the whole stated range lies above it.
By their numbers in this assay, from the lowest: compound 3; then compounds 1 and 2 (each within the scatter of the next).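

The earlier pair only exchanged one large group for another on this amine nitrogen, which left open whether such a group matters at all. In this assay, replacing the group with a hydrogen atom gives a 15-fold lower number from compound 2 to compound 3 (1.19 log units; beyond the scatter), and the same replacement of the larger group gives a 12-fold lower number from compound 1 to compound 3 (1.08 log units; beyond the scatter), so among these three compounds, inhibition is clearly stronger with the bare amine than with either large group. Nothing available here explains the size of these steps.

As far as these compounds go, what remains open is whether only hydrogen gives this lower number, or whether a small group such as methyl or acetyl on the same nitrogen would give it too. The compounds shown also cannot say how a short chain ending in a carboxylic acid would behave here.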